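From pyrrolidin-1-yl to piperidin-1-yl: an expected outcome

The compounds below may be only part of what the source reports. "The series", "measured", "known", "first", "only" and "open" are said of these compounds alone.

Compound 1 `CCC(=O)Nc1cccc(Oc2nc(Nc3ccc(N4CCCC4)cc3OC)ncc2Cl)c1` — in an assay on isolated protein for inhibition of NUAK family SNF1-like kinase 2 (Homo sapiens), read by ADP-Glo, with a stated time of 60 min, tested at 10 uM, in the presence of a further agent that is not named here (a higher number here means more inhibition at the concentration tested (going by the name of the read-out), a lower number less inhibition), compound 1 is reported as "not active" (no number reported)
Compound 2 `CCC(=O)Nc1cccc(Oc2nc(Nc3ccc(N(CC)CC)cc3)ncc2Cl)c1` — in this assay compound 2 gives 21.2%

Compound 1 stands without a single number: the report for it says only that it is not active. Compound 2 gives a modest percentage. Compound 3 `CCC(=O)Nc1cccc(Oc2nc(Nc3ccc(N4CCCCC4)cc3OC)ncc2Cl)c1` differs from compound 1 in one place: piperidin-1-yl in place of pyrrolidin-1-yl on an aromatic carbon. Among the measured compounds shown here, no step between measured compounds is available, and the change is small, so compound 3 is expected to move little in this assay, if at all beyond the scatter. Compound 3 is therefore estimated at 10%, with a range from 0% to 30%.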

Compound 3, a percentage reported as inhibition, at one concentration (the size of the read-out at that concentration, not a potency): "not active" (no number reported)
No number was reported for compound 3; the estimate stays without a comparison.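

In this assay, among the compounds shown here, compound 1 gives "not active" (no number reported) and compound 3 gives "not active" (no number reported), so no step between them can be read. The compounds shown leave open whether piperidin-1-yl in place of pyrrolidin-1-yl changes inhibition at all, and no further measurement bears on this result.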